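The compounds below may be only part of what the source reports. "The series", "measured", "known", "first", "only" and "open" are said of these compounds alone.

Measured so far:
compound 1, `COc1ccccc1Cc1cnc(CCc2ccc(-c3ccccc3C(=O)O)cc2)[nH]1`: 1720 nM
compound 2, `O=C(O)c1ccccc1-c1ccc(CCc2ncc(Cc3ccc(Cl)cc3)[nH]2)cc1`: 2290 nM

For the measured compounds named here, in an in vitro functional assay on cells for agonist activity at Bombesin receptor subtype-3 (Homo sapiens), read by luminescence and calcium flux (a higher number here means that more compound is needed for the effect, a lower number that less compound is needed), compound 2 gives the highest of the two numbers, but its only neighbour, compound 1, sits within the scatter of it, so the two cannot be told apart. Compound 3, `CC(C)CCc1cnc(CCc2ccc(-c3ccccc3C(=O)O)cc2)[nH]1`, is not yet measured. It differs from compound 2 by isobutyl in place of 4-chlorophenyl on a saturated chain carbon bound to an aromatic carbon. Going by the values given here, the one measured step at this place, a 1.3-fold higher number from compound 1 to compound 2 (0.12 log units; within the scatter), swapped one six-membered aromatic ring for another and stayed within the scatter. Dropping the ring altogether for a short branched chain goes further than that step, so a modest rise in the number seems more likely than a fall, though the evidence is thin. For compound 3 the expected value is 3500 nM, with a range of 1200 nM to 10000 nM, an estimated step of a 1.5-fold higher number from compound 2 to compound 3 (0.18 log units; within the scatter).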

Compound 3, half-maximal effective concentration: 119 nM
Estimate against measurement, compound 3: 29-fold (1.47 log units) above; the whole stated range lies above it.
By their numbers in this assay, from the lowest: compound 3; then compounds 1 and 2 (each within the scatter of the next).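

Replacing the aromatic ring with an open chain does far more at this place than exchanging one aromatic ring for another. Isobutyl in place of 4-chlorophenyl gives (a 19-fold lower number from compound 2 to compound 3 (1.28 log units; beyond the scatter)), and isobutyl in place of 2-methoxyphenyl gives (a 14-fold lower number from compound 1 to compound 3 (1.16 log units; beyond the scatter)), so this position responds strongly to change, which compounds 1 and 2 alone could not show. Nothing measured here explains why the number falls so far. From the compounds shown here alone, whether losing the ring or gaining the branched chain matters more stays open. A cyclohexyl ring, a longer chain or an amine at this place could help separate the two.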